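Taking the chloro off the sulfonyl aryl group

A few compounds are considered here, and "the series" means these few. Any claim that something is new, unique, unknown or untested is made for them only; others in the source may bear on it.

Among the compounds with values here, in a functional assay for binding affinity, with Homo sapiens as the target, read by fluorescence and flow cytometry (on this read-out lower numbers stand for tighter binding and higher numbers for weaker binding), compound 2 `O=C(NC[C@H](NS(=O)(=O)c1ccc(Cl)cc1)C(=O)O)c1cc2cc(CCC3CCNCC3)sc2s1` holds the lower of the two numbers so far, at 0.026 nM, while compound 1 `O=C(NC[C@H](NS(=O)(=O)c1cccs1)C(=O)O)c1cc2cc(CCC3CCNCC3)sc2s1` gives 0.15 nM. Compound 3 `O=C(NC[C@H](NS(=O)(=O)c1ccccc1)C(=O)O)c1cc2cc(CCC3CCNCC3)sc2s1` has hydrogen in place of chloro on an aromatic carbon. Within the data shown here, only one measured step bears on this change, a 5.8-fold lower number from compound 1 to compound 2 (0.76 log units; beyond the scatter), which is modest and beyond the scatter. That step replaces the whole thiophen-2-yl with 4-chlorophenyl, so it does not separate the ring from the chloro. Among the measured compounds shown here, no phenyl compound has been measured yet. Part of that step is expected to be given back, which points to a higher number in this assay of moderate size. The expected change is a 3.1-fold higher number from compound 2 to compound 3 (0.49 log units; beyond the scatter). Compound 3 is estimated at 0.08 nM, with an expected range of 0.03 nM to 0.2 nM.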

Compound 3, dissociation constant: 0.023 nM
Compound 3: the middle estimate sits 3.5-fold (0.54 log units) above what was measured, outside the stated range (below it).
By their numbers in this assay, from the lowest: compounds 3 and 2 (each within the scatter of the next); then compound 1.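

In this assay, hydrogen in place of chloro on the phenylsulfonyl group (giving a 1.1-fold lower number from compound 2 to compound 3 (0.05 log units; within the scatter)) leaves the read-out within the scatter, so in this pair the chloro makes no measurable difference at this place on the ring. The step that the earlier pair could not divide now separates: phenyl in place of thiophen-2-yl on the sulfonyl sulfur gives a 6.5-fold lower number from compound 1 to compound 3 (0.81 log units; beyond the scatter), which lies beyond the scatter, so the difference goes with the ring and not with the chloro. No measurement to hand offers a reason for either step.

Still open, on these data alone, is whether a methoxy, an amine or a carboxylic acid at this place on the six-membered aromatic ring would also match hydrogen and chloro. Also open, as far as these compounds go, is whether a pyridine ring in place of phenyl would keep the number of compound 3.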